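Swapping the aryl group on the piperazine of compound 1

The source may report more compounds than this note shows. Statements on the series, on what has been measured and on what is new or still open speak of the compounds shown alone.

Compound 1 (`CCCc1nc(-c2ccccc2)c(CNCCCN2CCN(c3ccccc3OC)CC2)o1`) was tested in an assay on HEK293 cells for inhibition of Voltage-dependent T-type calcium channel subunit alpha-1G (Homo sapiens), read by fluorescence, tested at 10 uM (on this read-out higher numbers stand for more inhibition at the one concentration tested (going by the name of the read-out) and lower numbers for less inhibition), and gave 41%. Two relatives were measured alongside it: compound 2 (`CCCc1nc(-c2ccccc2)c(CNCCN2CCN(c3ccccc3F)CC2)o1`), which gave 46.5%, and compound 3 (`CCCc1nc(-c2ccccc2)c(CNCCN2CCN(c3cccc(C(F)(F)F)c3)CC2)o1`), which gave 56.3%. On these three numbers compound 1 stands lowest; its gap to compound 2 lies within the scatter, while its gap to compound 3 lies beyond it.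

The new compound is compound 4 (`CCCc1nc(-c2ccccc2)c(CNCCCN2CCN(c3ccc(Cl)cc3)CC2)o1`). It keeps the shared core of compound 1 and changes one thing: 4-chlorophenyl in place of 2-methoxyphenyl on an amine nitrogen in a ring.

Going by the values given here, only one measured step exchanges the aryl group on that ring nitrogen, and it is a number 9.8 percentage points higher from compound 2 to compound 3 (within the scatter). That swap involved different groups from the present one, so it gives no firm direction, but it shows that such an exchange can leave the number where it was. Among the compounds with values here, there is no measured pair for the 4-chlorophenyl group itself.

The expectation for compound 4 is therefore a small step in this assay, a number 6 percentage points higher from compound 1 to compound 4 (within the scatter), with no confident direction. Compound 4 is estimated at 47%, within a range from 30% to 64%.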

Compound 4, a percentage reported as inhibition, at one concentration (the size of the read-out at that concentration, not a potency): 63.3%
For compound 4 the middle estimate is 16.3 percentage points below the measured one; the measured number falls inside the stated range.
By their numbers in this assay, from the lowest: compounds 1, 2, 3 and 4 (each within the scatter of the next, the first and the last beyond it).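

Compared with the earlier compounds, this result shows that the aryl group on the piperazine nitrogen can move the reading in this assay by more than the usual scatter. With the chain and the shared core held constant, the step is a number 22.3 percentage points higher from compound 1 to compound 4 (beyond the scatter) and it stands as the only listed step at this position to clear the scatter, whereas the step of a number 9.8 percentage points higher from compound 2 to compound 3 (within the scatter) does not. No measurement here accounts for the rise.

The change alters two things at once: the substituent on the phenyl ring goes from methoxy to chlorine, and its printed position goes from 2 to 4, so the compounds shown cannot separate the identity of the substituent from its place on the ring. A 2-chlorophenyl or a 4-methoxyphenyl group on the same chain would pull those two apart, and unsubstituted phenyl would show what either substituent adds, though each number here remains a reading at one concentration and not a potency.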